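This account rests on a few compounds, and the source may have more. Where it says the series, first, only, none or still open, it means among the compounds named here.

Compound 1 `O=C(CCCCC(S)CCS)Nc1ccccc1` and compound 2 `O=C(CCCCC(S)CCS)Nc1ccccc1Cl` share a core built around an amide and two free thiol groups; compound 2 carries chloro in place of hydrogen on an aromatic carbon, the change (chloro in place of hydrogen on an aromatic carbon). In a functional assay on Bel-7402 cells (Homo sapiens) for inhibition, read by MTT assay, with a stated time of 24 h, tested at 0.1 ug/mL (on this read-out lower numbers stand for less inhibition of growth and higher numbers for more inhibition of growth at the one concentration tested), compound 1 gives 0.85%, and compound 2 gives 5.11%, so the step of a number 4.3 percentage points higher from compound 1 to compound 2 (within the scatter) is small. Compound 3 `CC(=O)SCCC(CCCCC(=O)Nc1ccccc1)SC(C)=O` has a different core, and the difference between the two cores is not broken down here; in this assay compound 3 gives "not active" (no number reported), reported without a number. Compound 4 `CC(=O)SCCC(CCCCC(=O)Nc1ccccc1Cl)SC(C)=O` differs from compound 3 by chloro in place of hydrogen on an aromatic carbon, the same change. Because the earlier step of a number 4.3 percentage points higher from compound 1 to compound 2 (within the scatter) stayed within the scatter, compound 4 is expected to sit near compound 3, at around 4%, between 0% and 14%.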

Compound 4, percent growth inhibition at one concentration: 6.61%
Beside the measured number, compound 4's estimate is 2.6 percentage points below it, within the range that was stated.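

Among these compounds, compound 3 has no number, so no step from compound 3 to compound 4 can be read. The compounds shown leave open what chloro in place of hydrogen does to growth inhibition on the core of compound 3. No measurement given here speaks to a cause.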